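A few compounds are considered here, and "the series" means these few. Any claim that something is new, unique, unknown or untested is made for them only; others in the source may bear on it.

Measured in a functional assay on A549 cells (Homo sapiens) for antiproliferative activity, read by MTT assay, with a stated time of 48 h; on this read-out lower numbers stand for stronger inhibition and higher numbers for weaker inhibition:
- compound 1 `Cc1ccc(Oc2nc3ccccc3cc2/C=N/NC(=O)Cn2c([N+](=O)[O-])cnc2C)cc1`: 21500 nM
- compound 2 `COc1ccc(Oc2nc3ccccc3cc2/C=N/NC(=O)Cn2c([N+](=O)[O-])cnc2C)cc1`: 920 nM

Compound 2, at 920 nM, holds the lower of the two numbers. Compound 3 `Cc1ncc([N+](=O)[O-])n1CC(=O)N/N=C/c1cc2ccccc2nc1Oc1ccc(Cl)cc1` differs from it by chloro in place of methoxy on an aromatic carbon, with chloro in place of methoxy on an aromatic carbon. Within the data shown here, only one measured step bears on this place, the large 23-fold lower number from compound 1 to compound 2 (1.37 log units; beyond the scatter), where methoxy replaced methyl. Among the measured compounds shown here, no chloro compound has been measured, so that step shows sensitivity but gives no direct reading. A moderate rise in this assay, smaller than that step, is expected. The expected step is a 3.3-fold higher number from compound 2 to compound 3 (0.51 log units; beyond the scatter). For compound 3 the estimated value is 3000 nM, with an expected range of 700 nM to 14000 nM.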

Compound 3, half-maximal inhibitory concentration: 9030 nM
Compound 3: the middle estimate sits 3.0-fold (0.48 log units) below what was measured, within the range that was stated.
By their numbers in this assay, from the lowest: compound 2; then compound 3; then compound 1.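

In this assay, chloro in place of methoxy gives a 9.8-fold higher number from compound 2 to compound 3 (0.99 log units; beyond the scatter), while chloro in place of methyl gives a 2.4-fold lower number from compound 1 to compound 3 (0.38 log units; beyond the scatter). At this aromatic carbon the three groups are now ordered, with methoxy giving the lowest number, then chloro, then methyl, and chloro lying closer to methyl than to methoxy. No available evidence accounts for this order. The compounds shown leave open whether an ethoxy group, a hydroxyl or an amine at this carbon would give a number as low as methoxy does.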